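The source may hold more compounds than are shown below. What is called first, only, known or untested is meant among the compounds shown, and "the series" means these compounds.

Measured compounds: compound 1 `CCOc1ccc(-n2nncc2CN2C(=O)C3(C(C#N)=C(N)Oc4c(N)cc5nc6ccccc6nc5c43)c3ccccc32)cc1` gives 26800 nM in a functional assay on MCF7 cells (Homo sapiens) for antiproliferative activity, read by MTT assay, with a stated time of 48 h; on this read-out lower numbers stand for stronger inhibition and higher numbers for weaker inhibition; compound 2 `COc1ccc(OC)c(-n2nncc2CN2C(=O)C3(C(C#N)=C(N)Oc4c(N)cc5nc6ccccc6nc5c43)c3ccccc32)c1` gives 28100 nM in this assay.

Compound 2 stands level with compound 1, since a 1.0-fold higher number from compound 1 to compound 2 (0.02 log units; within the scatter) is within the scatter. Compound 3 `N#CC1=C(N)Oc2c(N)cc3nc4ccccc4nc3c2C12C(=O)N(Cc1cnnn1-c1c(Cl)cc(Cl)cc1Cl)c1ccccc12` differs from compound 2 by 2,4,6-trichlorophenyl in place of 2,5-dimethoxyphenyl on an aromatic nitrogen. For the measured compounds named here, the only measured step, from one substituent to another on the same aromatic nitrogen, bears on this change and was within the scatter; no trichlorophenyl analogue has been measured. It is therefore expected that compound 3 shows no step beyond the scatter in this assay, a 1.0-fold lower number from compound 2 to compound 3 (0.02 log units; within the scatter). Compound 3 is estimated at 27000 nM, with a range from 9000 nM to 80000 nM.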

Compound 3, half-maximal inhibitory concentration: 37800 nM
The estimate for compound 3 lay 1.4-fold (0.15 log units) below the measured number; measured number inside the range.
By their numbers in this assay, from the lowest: compounds 1, 2 and 3 (each within the scatter of the next).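

In this assay, the position on the aromatic nitrogen takes 2,4,6-trichlorophenyl with a 1.3-fold higher number from compound 2 to compound 3 (0.13 log units; within the scatter) and a 1.4-fold higher number from compound 1 to compound 3 (0.15 log units; within the scatter). The three compounds thus stay level even when chlorine replaces the oxygen-bearing substituents and the aryl group has no hydrogen-bond acceptors. No evidence bears on why these numbers stay level.

The compounds shown leave open whether any group on this nitrogen can move the number beyond the scatter, since all three carry a substituted phenyl. From the compounds shown here alone, a phenyl bearing an amine or a carboxylic acid remains untested here.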